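Adding ethyl to the chain of compound 2

The compounds below may be only part of what the source reports. "The series", "measured", "known", "first", "only" and "open" are said of these compounds alone.

Compound 1 `CCCCCCC(CCO)n1cnc2c(Cl)ncnc21`: 16700 nM
Compound 2 `CCCCCCC(CCO)n1cnc2c(N(C)C)ncnc21`: > 50000 nM
Compound 3 `CCCCCCC(CCO)n1cnc2cncnc21`: > 50000 nM

These values come from a functional assay on SW480 cells (Homo sapiens) for antiproliferative activity, read by MTT assay, with a stated time of 48 h; a higher number here means a weaker inhibitor, a lower number a stronger inhibitor. Compound 2 stands at > 50000 nM, which is a limit and not a number. From the compounds shown here alone, it sits at the limit of > 50000 nM in this assay, at which 2 of the 3 values shown sit, so its true position is unknown.

Compound 4 `CCCCCCCCC(CCO)n1cnc2c(N(C)C)ncnc21` differs from compound 2 by ethyl in place of hydrogen on a saturated chain carbon, seven bonds along the chain from an aromatic nitrogen. Cut one bond further out, the same difference reads propyl to pentyl.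

The measured steps all change the group on the core and leave the chain alone. They are an at least 2.9-fold higher number from compound 1 to compound 2 (0.47 log units; beyond the scatter) and an at least 2.9-fold higher number from compound 1 to compound 3 (0.47 log units; beyond the scatter), both beyond the scatter, while a step that the two limits leave unreadable from compound 2 to compound 3 cannot be sized. None of them gives a size for a change in the chain, so only a small move towards a lower number is expected, and possibly none that can be read. The expected result is an at least 1.2-fold lower number from compound 2 to compound 4 (0.09 log units; that floor lies within the scatter). Compound 4 is estimated at 40000 nM, with an expected range of 15000 nM to 80000 nM.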

Compound 4, half-maximal inhibitory concentration: 21600 nM
Compound 4: middle estimate off by 1.9-fold (0.27 log units), on the high side; the range from low to high includes it.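

In this assay, among the compounds shown here, the earlier steps all changed the group on the core, and this is the first one that changes the chain: ethyl in place of hydrogen on a saturated chain carbon, seven bonds along the chain from an aromatic nitrogen, gives an at least 2.3-fold lower number from compound 2 to compound 4 (0.36 log units; beyond the scatter). With dimethylamino held on the core, the chain therefore matters to the read-out, and the longer chain brings a measurable value where compound 2 gave none. The step has only a floor and its true size is unknown, since the value of compound 2 is a limit: the limit of > 50000 nM in this assay, at which 2 of the 4 values shown sit.

From the compounds shown here alone, whether a still longer chain would carry the move further, and whether the same ethyl would act alike with chloro or hydrogen on the core, stays open. Going by these compounds, what an amine or a carboxylic acid on the chain would do is also open.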